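A ring change on the shared core and expected solubility

The compounds below may be only part of what the source reports. "The series", "measured", "known", "first", "only" and "open" are said of these compounds alone.

Measured compounds:
compound 1 `CS(=O)(=O)Cc1cc(C2=CCOCC2)nc(-c2cccc(O)c2)n1` gives 27 ug/mL in a physicochemical assay for solubility, in phosphate buffer, measured as kinetic solubility, with a stated time of 1 h, at pH 7.4; on this read-out lower numbers stand for lower solubility and higher numbers for higher solubility;
compound 2 `Oc1cccc(-c2nccc(C3=CCOCC3)n2)c1` gives 113 ug/mL in this assay;
compound 3 `CCNC(=O)Nc1ccc(-c2nc(C(C)(C)S(C)(=O)=O)cc([C@]34CCOC[C@H]3C4)n2)cc1` gives 74 ug/mL in this assay.

Compound 1 stands lowest of the three numbers; compound 3 is nearest to it and compound 2 furthest. Among the compounds with values here, the one step measured between compounds that differ in a single place is a 4.2-fold higher number from compound 1 to compound 2 (0.62 log units; beyond the scatter), a change at a different position from the one now in question, so it does not speak directly to compound 4.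

Compound 4 `CS(=O)(=O)Cc1cc([C@@]23CCOC[C@@H]2C3)nc(-c2cccc(O)c2)n1` differs from compound 1 by a group of 7 heavy atoms (6 carbon, 1 oxygen; one three-membered non-aromatic ring of carbon only, one six-membered non-aromatic ring with 1 hetero atom) in place of a group of 6 heavy atoms (5 carbon, 1 oxygen; one six-membered non-aromatic ring with 1 hetero atom), on an aromatic carbon. Within the data shown here, compound 3 carries the same entering group and gives 74 ug/mL, but it differs from compound 1 in several further places, so no measured step bears on this change. The expectation is therefore a step of a 1.1-fold higher number from compound 1 to compound 4 (0.05 log units; within the scatter), which is within the scatter. Compound 4 is estimated at 30 ug/mL, with a range from 11 ug/mL to 85 ug/mL.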

Compound 4, solubility: 145 ug/mL
For compound 4 the middle estimate is 4.8-fold (0.68 log units) below the measured one, and the stated range ends below it.
By their numbers in this assay, from the lowest: compound 1; then compounds 3, 2 and 4 (each within the scatter of the next).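

Within the data shown here, the change at the aromatic carbon next to the ring nitrogen gives a 5.4-fold higher number from compound 1 to compound 4 (0.73 log units; beyond the scatter) in this assay, the first measured step at this place, since the earlier step concerned the (methylsulfonyl)methyl group. With that group and the 3-hydroxyphenyl group unchanged, the difference in the read-out follows the exchange of one ring group for the other. That exchange brings several differences at once, namely the three-membered ring of carbon only, the loss of the double bond outside aromatic rings and the two defined stereocentres, and this single step does not separate them. Nothing measured here accounts for the size of the step.

From the compounds shown here alone, it remains open whether the same exchange would give a step of similar size in compound 2, where hydrogen stands in place of the (methylsulfonyl)methyl group. The compounds shown also leave open how a morpholine or a simple amine at this aromatic carbon would compare, and how the opposite stereoisomer of the entering group would read.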